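Acetyl replacing fluoro on the fused core: lipophilicity expectation

The source may report more compounds than this note shows. Statements on the series, on what has been measured and on what is new or still open speak of the compounds shown alone.

Measured compounds:
- Compound 1 `CC(=O)NCc1cccc(Cn2nc(NS(=O)(=O)c3ccc(Cl)s3)c3c(F)cccc32)c1`: in a physicochemical assay for lipophilicity (on this read-out lower numbers stand for lower lipophilicity and higher numbers for higher lipophilicity), compound 1 gives 3
- Compound 2 `CC(=O)NCc1cccc(Cn2nc(NS(=O)(=O)c3ccc(Cl)s3)c3c(C#N)cccc32)c1`: in this assay compound 2 gives 2.5

Compound 1 stands highest of the two numbers in this assay; its nearest neighbour is compound 2, and the step of a number 0.50 log units lower from compound 1 to compound 2 (beyond the scatter) is beyond the scatter. For the measured compounds named here, that step, cyano in place of fluoro on an aromatic carbon, is the only measured change that bears on the unmeasured compound 3 `CC(=O)NCc1cccc(Cn2nc(NS(=O)(=O)c3ccc(Cl)s3)c3c(C(C)=O)cccc32)c1`.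

Compound 3 differs from compound 1 by acetyl in place of fluoro on an aromatic carbon. Both the cyano of compound 2 and the acetyl of compound 3 replace the same fluoro at the same place on the shared core, so the measured step of a number 0.50 log units lower from compound 1 to compound 2 (beyond the scatter) is the closest guide. Because a number 0.50 log units lower from compound 1 to compound 2 (beyond the scatter) was modest but clearly beyond the scatter, a downward step of similar or slightly larger size is expected in this assay for compound 3.

For compound 3 the expected step is a number 0.65 log units lower from compound 1 to compound 3 (beyond the scatter). Compound 3 is therefore estimated at 2.35 in this assay, with a range from 1.9 to 2.8.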

Compound 3, distribution coefficient: 4.8
For compound 3 the middle estimate is 2.45 log units below the measured one, outside the stated range (above it).
By their numbers in this assay, from the lowest: compound 2; then compound 1; then compound 3.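

Replacing fluoro with acetyl on this aromatic carbon gives a number 1.80 log units higher from compound 1 to compound 3 (beyond the scatter) in this assay and replacing cyano with acetyl at the same place gives a number 2.30 log units higher from compound 2 to compound 3 (beyond the scatter) in the same read-out, so exchanging the fluoro does not fix the direction of the change: cyano lowers the number and acetyl raises it. For the compounds shown here, both new steps are large, while the one step available before, a number 0.50 log units lower from compound 1 to compound 2 (beyond the scatter), was modest, which shows that the numbers at this single position spread much more widely than that step alone suggested, with the acetyl of compound 3 now highest of the three. Nothing among the data shown accounts for this rise.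

With only fluoro, cyano and acetyl shown at this carbon, it remains open whether a propanoyl group, a methyl ester or a primary carboxamide would stand near compound 3 or near compound 2 in this assay. As far as these compounds go, it also remains open whether acetyl in place of fluoro would give a step of this direction and size on a different aromatic carbon of the shared core, or with another group in place of the chlorothiophene sulfonamide.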